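The compounds below may be only part of what the source reports. "The series", "measured", "known", "first", "only" and "open" are said of these compounds alone.

Working notes. The shared core carries at one aromatic carbon a 2-phenylethynyl group in compound 1 `Nc1ncnn2c([C@@H]3O[C@H](CO)[C@@H](O)[C@H]3O)cc(C#Cc3ccccc3)c12`, a 4-fluorophenyl in compound 2 `Nc1ncnn2c([C@@H]3O[C@H](CO)[C@@H](O)[C@H]3O)cc(-c3ccc(F)cc3)c12`, a 2-fluorophenyl in compound 3 `Nc1ncnn2c([C@@H]3O[C@H](CO)[C@@H](O)[C@H]3O)cc(-c3ccccc3F)c12` and a 2-chlorophenyl in compound 4 `Nc1ncnn2c([C@@H]3O[C@H](CO)[C@@H](O)[C@H]3O)cc(-c3ccccc3Cl)c12`. In a functional assay on Z-138 cells (Homo sapiens) for antiproliferative activity, with a stated time of 72 h (a lower number here means a stronger inhibitor, a higher number a weaker inhibitor), compound 1 gives 41400 nM and compound 3 gives 95300 nM. For compound 2 this assay reports only a limit, > 100000 nM (the limit of > 100000 nM in this assay, at which 1 of the 3 values shown sits). Of the two numbers compound 3 has the higher: a 2.3-fold higher number from compound 1 to compound 3 (0.36 log units; beyond the scatter). The remaining steps are an at least 2.4-fold higher number from compound 1 to compound 2 (0.38 log units; beyond the scatter) and an at least 1.0-fold lower number from compound 2 to compound 3 (0.02 log units; that floor lies within the scatter). Compound 4 differs by chloro in place of fluoro on an aromatic carbon. Among the compounds with values here, no measured step exchanges one halogen for another, so nothing here fixes the size of this change; the expectation is a step within the scatter, a 1.2-fold lower number from compound 3 to compound 4 (0.08 log units; within the scatter). Compound 4 is therefore estimated near 80000 nM, between 30000 nM and 200000 nM.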

Compound 4, half-maximal inhibitory concentration: 76100 nM
Compound 4: the middle estimate sits 1.1-fold (0.02 log units) above what was measured, within the range that was stated.
By their numbers in this assay, from the lowest: compounds 1, 4 and 3 (each within the scatter of the next, the first and the last beyond it). At a limit, above all of these: compound 2.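

In this assay, chloro in place of fluoro on an aromatic carbon, ortho to a large group, is a step within the scatter: a 1.3-fold lower number from compound 3 to compound 4 (0.10 log units; within the scatter). The two halogens are not told apart at this place. Within the data shown here, the exchange of 2-phenylethynyl for 2-chlorophenyl is the first exchange of that group to stay within the scatter: a 1.8-fold higher number from compound 1 to compound 4 (0.26 log units; within the scatter). The remaining step can be given only as a floor: an at least 1.3-fold lower number from compound 2 to compound 4 (0.11 log units; that floor lies within the scatter). Compound 2 has only a limit: the limit of > 100000 nM in this assay, at which 1 of the 4 values shown sits.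

Left open is whether an amine, a methoxy group or a carboxylic acid in place of the halogen would shift the number beyond the scatter.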